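The compounds below may be only part of what the source reports. "The series", "measured", "known", "first", "only" and "open" are said of these compounds alone.

Compounds measured so far in an ADME assay on A549 cells (Homo sapiens) for cytotoxicity, read by MTT assay, with a stated time of 72 h (on this read-out higher numbers stand for weaker inhibition and lower numbers for stronger inhibition), are these:

Compound 1 `O=C(NNC(=O)c1ccccc1[N+](=O)[O-])c1ccc(-n2cccc2)cc1` gives 205000 nM
Compound 2 `CC(=O)N1N=C(c2ccc(-n3c(C)ccc3C)cc2)OC1c1cccc([N+](=O)[O-])c1` gives 197000 nM
Compound 3 `Cc1ccc(C)n1-c1ccc(C(=O)N/N=C/c2ccc(O)cc2)cc1` gives "not determined" (no result reported)

Within the data shown here, only two of these three compounds carry a number, as no result was reported for compound 3. Compound 2 stands at 197000 nM and compound 1 stands at 205000 nM in this assay and these two values lie within the scatter of each other, so the two compounds sit level on the available numbers.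

Compound 4 `CC(=O)N1N=C(c2ccc(-n3c(C)ccc3C)cc2)OC1c1c(Cl)cccc1Cl` has not yet been measured. It keeps the rest of compound 2, including the acetyl group, and differs in one place: 2,6-dichlorophenyl in place of 3-nitrophenyl on a saturated ring carbon in a five-membered non-aromatic ring with 2 nitrogen and 1 oxygen.

Among the measured compounds shown here, no measured pair here differs in one place, so the data show nothing about what such a change does. The expectation therefore starts from compound 2 at 197000 nM and assumes no step beyond the scatter, in either direction. The estimated change is a 1.1-fold lower number from compound 2 to compound 4 (0.04 log units; within the scatter) and it is expected to be small. For compound 4 the expected value is 180000 nM in an estimated range from 80000 nM to 350000 nM in this assay when it is measured.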

Compound 4, half-maximal inhibitory concentration: 224000 nM
Compound 4: the middle estimate sits 1.2-fold (0.09 log units) below what was measured, and the stated range covers the measured number.
By their numbers in this assay, from the lowest: compounds 2, 1 and 4 (each within the scatter of the next).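

In this assay, among these compounds, the exchange of 3-nitrophenyl for 2,6-dichlorophenyl on the saturated ring carbon provides the first comparison between compounds that differ in one place, with a 1.1-fold higher number from compound 2 to compound 4 (0.06 log units; within the scatter) as its measured step. This places compound 2 and compound 4 level, which shows that, with the acetyl group and the rest of the molecule kept, this position can carry either of these two aromatic groups without a measurable difference in this read-out. The level result holds even though 3-nitrophenyl has hydrogen-bond acceptors and 2,6-dichlorophenyl has none, but no measurement given here accounts for the match.

On these data alone, a single exchange between two substituted phenyl groups cannot show whether this position is insensitive in general, and it remains open whether a phenyl group bearing an amine or a carboxylic acid on this saturated ring carbon would stay level with compound 2. As far as these compounds go, it is equally open whether a longer chain in place of the acetyl group would alter the number, or would change how this position responds to the same exchange.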